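Same Chain Rearrangement Tried on a Second Core

The compounds below may be only part of what the source reports. "The series", "measured", "known", "first", "only" and "open" are said of these compounds alone.

Measured so far:
compound 1 `CC(Cc1ccc(NCc2cccc(Oc3ccccc3)c2)cc1)C(=O)O` gives 70%
compound 2 `Cc1nc(-c2ccc(C(F)(F)F)cc2)sc1CNc1ccc(CC(C)C(=O)O)cc1` gives 100%
compound 3 `CC(CC(=O)O)c1ccc(NCc2cccc(Oc3ccccc3)c2)cc1` gives 83%

All three were tested in a functional assay on CHO cells for agonist activity at Free fatty acid receptor 1 (Homo sapiens), read by a luciferase reporter; on this read-out lower numbers stand for smaller maximal responses and higher numbers for larger maximal responses. Compound 1 and compound 3 share a core and differ in one place: 1-(carboxymethyl)ethyl in place of 2-carboxypropyl on an aromatic carbon. This change gave a number 13 percentage points higher from compound 1 to compound 3 (beyond the scatter). Compound 2 sits on a different core, and the difference between the two cores is not broken down here; compound 2 reaches the highest number of the three.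

Compound 4 `Cc1nc(-c2ccc(C(F)(F)F)cc2)sc1CNc1ccc(C(C)CC(=O)O)cc1` is not yet measured. It is obtained from compound 2 by the same change: 1-(carboxymethyl)ethyl in place of 2-carboxypropyl on an aromatic carbon. Because compound 1 to compound 3 gave a number 13 percentage points higher from compound 1 to compound 3 (beyond the scatter), a step of similar sign is expected, yet compound 2 already gives 100%, which leaves little room above. The expected step is therefore no change at the digits printed from compound 2 to compound 4 (within the scatter), and compound 4 is estimated at 100%, between 85% and 115%.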

Compound 4, largest response reached (reported as percent of maximum), in percent of the reference or control that the assay uses: 109%
The estimate for compound 4 lay 9 percentage points below the measured number, and the stated range covers the measured number.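

In this assay, putting 1-(carboxymethyl)ethyl in place of 2-carboxypropyl on the second core gave a number 9 percentage points higher from compound 2 to compound 4 (within the scatter). The steps on the two cores cannot be told apart: the same change on two cores in this assay, a number 13 percentage points higher (beyond the scatter) from compound 1 to compound 3 and a number 9 percentage points higher (within the scatter) from compound 2 to compound 4, 4 percentage points apart, within the scatter of two such steps. Among the compounds shown here, this shows no sign that the core alters the effect of the change, but it does not prove that the increase carries over, as only the step on the first core lies beyond the scatter, and two cores cannot establish a rule for the whole series.

The compounds shown leave open how a longer chain, such as 3-carboxypropyl, would behave on either core. They also leave open whether the same change would hold if a tetrazole replaced the carboxylic acid.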